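Imidazole swap at the chain carbon: compound 2 to compound 3

The source may hold more compounds than are shown below. What is called first, only, known or untested is meant among the compounds shown, and "the series" means these compounds.

Compound 1 `CCc1nccn1C[C@@]1(c2ccc(Cl)cc2Cl)OC[C@@H](COc2ccc(N3CCN(c4ccc(-n5cnn(C(C)CC)c5=O)cc4)CC3)cc2)O1` in a functional assay on HUVEC cells (Homo sapiens), read by scintillation counting and thymidine incorporation, with a stated time of 24 h; a lower number here means a stronger inhibitor, a higher number a weaker inhibitor: 224 nM
Compound 2 `CCC(C)n1ncn(-c2ccc(N3CCN(c4ccc(OC[C@@H]5CO[C@@](Cn6cnc(C)c6)(c6ccc(Cl)cc6Cl)O5)cc4)CC3)cc2)c1=O` in this assay: 102 nM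

Compound 2 holds the lower of the two numbers in this assay. Compound 3 `CCC(C)n1ncn(-c2ccc(N3CCN(c4ccc(OC[C@@H]5CO[C@@](Cn6cc(C(F)(F)F)nc6C)(c6ccc(Cl)cc6Cl)O5)cc4)CC3)cc2)c1=O` carries 2-methyl-4-(trifluoromethyl)-1H-imidazol-1-yl in place of 4-methyl-1H-imidazol-1-yl on a saturated chain carbon bound to a saturated ring carbon. Within the data shown here, one measured step bears on this place: a 2.2-fold lower number from compound 1 to compound 2 (0.34 log units; beyond the scatter), modest, where 4-methyl-1H-imidazol-1-yl replaced 2-ethyl-1H-imidazol-1-yl. Among the measured compounds shown here, no measured compound carries trifluoromethyl, so the direction is uncertain. Reading that step backwards, a move of similar size toward a higher number is expected: a 2.1-fold higher number from compound 2 to compound 3 (0.31 log units; beyond the scatter). For compound 3 the estimate is 210 nM, with an expected range of 70 nM to 600 nM.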

Compound 3, half-maximal inhibitory concentration: 441 nM
For compound 3 the middle estimate is 2.1-fold (0.32 log units) below the measured one; the measured number falls inside the stated range.
By their numbers in this assay, from the lowest: compound 2; then compounds 1 and 3 (each within the scatter of the next).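

In this assay, 4-methyl-1H-imidazol-1-yl stays ahead of both other imidazoles on the saturated chain carbon, with the new group giving a 4.3-fold higher number from compound 2 to compound 3 (0.64 log units; beyond the scatter). Against the ethyl-bearing imidazole the new group shows a 2.0-fold higher number from compound 1 to compound 3 (0.29 log units; within the scatter), so these two cannot be separated here. Nothing at hand accounts for either step.

Going by these compounds, the new group differs from 4-methyl-1H-imidazol-1-yl in two features at once, so the share of trifluoromethyl in the step stays open. The simple 2-methyl-1H-imidazol-1-yl would help to divide that share.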